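Isopropylcarbamoyl in Place of Pyridinyl on a Benzisoxazole Acid

The compounds below may be only part of what the source reports. "The series", "measured", "known", "first", "only" and "open" are said of these compounds alone.

Measured compounds:
compound 1, `COC(=O)/C=C/c1ccc2noc(-c3ccccc3)c2c1`, 12100 nM
compound 2, `Cc1ccc(-c2onc3ccc(/C=C/C(=O)O)cc23)cc1`, 11500 nM
compound 3, `O=C(O)c1ccc2noc(-c3ccc(-c4ccncc4)cc3)c2c1`, 670 nM

In an assay for inhibition of inositol hexakisphosphate kinase 3 (Homo sapiens), read by colorimetric assay, coupled enzyme assay and malachite green, with a stated time of 120 min, in the presence of a further agent that is not named here (on this read-out lower numbers stand for stronger inhibition and higher numbers for weaker inhibition), compound 1 gives 12100 nM and compound 2 gives 11500 nM; these two values lie within the scatter of each other. Compound 3, in this assay, gives 670 nM, the lowest of the three numbers, and its gap to compound 2 and to compound 1 is in each case beyond the scatter, so compound 3 stands as the most potent of the set shown.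

Compound 4, `CC(C)NC(=O)c1ccc(-c2onc3ccc(C(=O)O)cc23)cc1`, has not yet been measured. It differs from compound 3 in one place: isopropylcarbamoyl in place of pyridin-4-yl on an aromatic carbon. Among the measured compounds shown here, no measured pair shows this kind of exchange, so the size of its effect is open. Given that compound 3 already gives 670 nM, the author expects a modest move toward a higher number, a step of a 2.2-fold higher number from compound 3 to compound 4 (0.35 log units; beyond the scatter) that may not exceed the scatter. For compound 4 the estimate in this assay is 1500 nM, with a range from 400 nM to 6000 nM.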

Compound 4, half-maximal inhibitory concentration: 340 nM
Compound 4: the middle estimate sits 4.4-fold (0.64 log units) above what was measured; measured number outside the range, below it.
By their numbers in this assay, from the lowest: compounds 4 and 3 (each within the scatter of the next); then compounds 2 and 1 (each within the scatter of the next).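

In this assay, isopropylcarbamoyl in place of pyridin-4-yl, on an aromatic carbon para to a large group, gives a 2.0-fold lower number from compound 3 to compound 4 (0.29 log units; within the scatter). Among the compounds shown here, this is the first pair to differ at this position alone, and it shows that the aromatic ring of compound 3 can give way to a group with no ring and the same count of heavy atoms without a change that can be told from the scatter. The exchange also brings in a hydrogen-bond donor and a double bond outside aromatic rings, yet nothing shown bears on what either contributes to the reading.

The compounds shown leave open whether the amide hydrogen matters, which dimethylcarbamoyl at this position would test. They also leave open how the value responds to a smaller group, such as methyl, or to a longer chain on the amide.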